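Fixing One Stereocentre in Compound 2

A few compounds are considered here, and "the series" means these few. Any claim that something is new, unique, unknown or untested is made for them only; others in the source may bear on it.

In a functional assay on A-375 cells (Homo sapiens) for activation, with a stated time of 3 days (a lower number here means that less compound is needed, a higher number that more compound is needed for the effect), compound 1 `O=C(Nc1ccc(-c2ccccc2)cc1)C1CCCN(Cc2ccc(F)c(F)c2)C1` gives 5000 nM, while compound 2 `O=C(Nc1ccc(-c2ccc[nH]2)cc1)C1CCCN(Cc2ccc(F)c(F)c2)C1` gives 720 nM. For the measured compounds named here, compound 2 thus holds the lower of the two numbers measured so far. The step between them, with 1H-pyrrol-2-yl in place of phenyl on an aromatic carbon, is a 6.9-fold lower number from compound 1 to compound 2 (0.84 log units; beyond the scatter).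

Compound 3 `O=C(Nc1ccc(-c2ccc[nH]2)cc1)[C@H]1CCCN(Cc2ccc(F)c(F)c2)C1` has not yet been measured. Set against compound 2, it shows this difference: the two compounds have the same atoms and bonds; at least one stereo element is drawn with a configuration in one of them and without one in the other: 1 of 1 stereo elements differ; a stereocentre at a saturated ring carbon is drawn without a configuration in compound 2 and S in compound 3. Going by the values given here, the one measured step changes a different place and offers no direct guide to a change of configuration. Among the compounds with values here, no measured pair shows how the configuration at this saturated ring carbon affects the number, nor which configuration is favoured. A small step toward a lower number is therefore expected in this assay, possibly no larger than the scatter, although a move to a higher number cannot be ruled out. For compound 3 the expected value is 450 nM, with an estimated range of 150 nM to 2000 nM. The expected change is a 1.6-fold lower number from compound 2 to compound 3 (0.20 log units; within the scatter).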

Compound 3, half-maximal effective concentration: 140 nM
Estimate against measurement, compound 3: 3.2-fold (0.51 log units) above; measured number below the stated range.
By their numbers in this assay, from the lowest: compound 3; then compound 2; then compound 1.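

In this assay, setting the saturated ring carbon as S gives a 5.1-fold lower number from compound 2 to compound 3 (0.71 log units; beyond the scatter), with the atoms and bonds unchanged. For the compounds shown here, the earlier compounds showed only that the number responds to the aromatic group, through 1H-pyrrol-2-yl in place of phenyl, and gave no sign that the configuration at this carbon mattered; this step shows that it does, and that a change of configuration alone can move the number beyond the scatter. The only difference the structures offer to account for this step is the following: the fact that one of compounds 2 and 3 is drawn with a defined configuration and the other without, at the place where they differ

The compounds shown leave open how the R configuration at this carbon would read, and so how far the two configurations stand apart. They also leave open whether the S configuration would still bring a lower number with phenyl in place of 1H-pyrrol-2-yl, or with another group there, such as an amine or a carboxylic acid.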